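The source may report more compounds than this note shows. Statements on the series, on what has been measured and on what is new or still open speak of the compounds shown alone.

Compound 1 `CCOC(=O)c1c(-c2ccc(Cl)cc2)[nH]c2cccc(OC)c2c1=O` is the starting point. In a physicochemical assay for solubility, in phosphate buffer, at pH 7.4 (a higher number here means a more soluble compound, a lower number a less soluble compound), compound 1 gives > 100000 nM, which is a limit of the assay rather than a number. Among the three measured values compound 1 is the only one sitting at that limit (the limit of > 100000 nM in this assay, at which 1 of the 3 values shown sits). Compound 2 `CCOC(=O)c1c(-c2ccc(C(C)(C)C)cc2)[nH]c2cccc(OC)c2c1=O` gives 1000 nM in this assay, and compound 3 `CCOC(=O)c1c(-c2ccc(C(F)(F)F)cc2)[nH]c2cccc(OC)c2c1=O` gives 22000 nM. Both measured steps that begin at compound 1 lowered the number: an at least 100-fold lower number from compound 1 to compound 2 (2.00 log units; beyond the scatter) and an at least 4.5-fold lower number from compound 1 to compound 3 (0.65 log units; beyond the scatter). Between the two replacements themselves lies a 22-fold higher number from compound 2 to compound 3 (1.34 log units; beyond the scatter), so the size of the drop depended strongly on which group replaced chloro.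

Compound 4 `CCOC(=O)c1c(-c2cccc(C)c2)[nH]c2cccc(OC)c2c1=O` has not yet been measured. It differs from compound 1 in one place: 3-methylphenyl in place of 4-chlorophenyl on an aromatic carbon. Going by the values given here, a methyl group on that phenyl ring has no measured counterpart here, so the bearing steps only show that the two replacements tried so far each lowered the number, one by a large and one by at least a modest amount. Because compound 1 gives > 100000 nM, the step to compound 4 is expected to be small, as a number no higher from compound 1 to compound 4 (the limit leaves the size open). Compound 4 is therefore estimated at 100000 nM, with a range from 30000 nM to 300000 nM.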

Compound 4, solubility: > 100000 nM
Compound 4 gave a limit, no number; the forecaster's own chance of this, stated with the estimate: 50%; the middle value sits exactly at the limit.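

In this assay compound 4 gives > 100000 nM, a limit and not a number. Going by these compounds alone, compound 1 gives > 100000 nM, also a limit, so no step from compound 1 to compound 4 can be read: the limit of > 100000 nM in this assay, at which 2 of the 4 values shown sit. The compounds shown leave open whether 3-methylphenyl in place of 4-chlorophenyl changes the number at all, and by how much.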